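The compounds below may be only part of what the source reports. "The series", "measured", "known", "first", "only" and "open" are said of these compounds alone.

Measured so far in a toxicity assay on HT-29 cells (Homo sapiens) for cytotoxicity (a higher number here means that more compound is tolerated, a lower number that less compound is tolerated), where every value is a limit:
- Compound 1 `CCCCn1nc(C(=O)N[C@H]2COc3ccccc3N(C)C2=S)nc1Cc1ccccc1`: > 100000 nM
- Compound 2 `CN1C(=S)[C@@H](NC(=O)c2nc(Cc3ccccc3)n(CCCCCC#N)n2)COc2ccccc21`: > 100000 nM
- Compound 3 `CN1C(=S)[C@@H](NC(=O)c2nc(Cc3ccccc3)n(CC3COC3)n2)COc2ccccc21`: > 100000 nM

Compound 3 has no exact number, only the limit of > 100000 nM. The whole set shares this position, as the limit of > 100000 nM in this assay, at which 3 of the 3 values shown sit, shows.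

The next compound, compound 4 `CN1C(=S)[C@@H](NC(=O)c2nc(Cc3ccccc3)n(C3CCNC3)n2)COc2ccccc21`, has pyrrolidin-3-yl in place of (oxetan-3-yl)methyl on an aromatic nitrogen. The rest of the molecule stays the same.

Among the compounds with values here, three measured steps bear on this change, since each alters the group on that same aromatic nitrogen: a step that the two limits leave unreadable from compound 1 to compound 2, a step that the two limits leave unreadable from compound 1 to compound 3 and a step that the two limits leave unreadable from compound 2 to compound 3. None of them has a readable size, but none moved a compound off the limit in this assay. Within the data shown here, no measured compound carries pyrrolidin-3-yl, so this new group remains an open question and the range has to stay wide, reaching further down than up.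

The expected result is a number no higher from compound 3 to compound 4 (the limit leaves the size open), which means no clear step beyond the usual scatter is expected. For compound 4 the estimated value is 100000 nM, with an expected range from 30000 nM to 200000 nM.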

Compound 4, half-maximal cytotoxic concentration: > 100000 nM
Compound 4 ended at the assay's limit; the forecaster's own chance of this, stated with the estimate: 80%; the middle value sits exactly at the limit.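

In this assay compound 4 gives > 100000 nM, which is a limit and not a number. The steps joining compound 4 to compound 1, compound 2 and compound 3 therefore cannot be read, and the set stays at one position: the limit of > 100000 nM in this assay, at which 4 of the 4 values shown sit. The compounds shown leave open the exact value of each one in this assay, and whether any group on that aromatic nitrogen would bring a compound off the limit.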